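Methoxy to Nitro: An Expected Lipophilicity Step

The source may report more compounds than this note shows. Statements on the series, on what has been measured and on what is new or still open speak of the compounds shown alone.

In a physicochemical assay for lipophilicity, using the shake flask method, in phosphate buffer, measured as octanol-water partition, with a stated time of 5 h (a higher number here means a more lipophilic compound, a lower number a more polar compound), compound 2 `COc1ccc(/C=C/C(=O)c2ccc(NC(=O)CN3CCN(c4cc5c(cc4F)c(=O)c(C(=O)O)cn5C4CC4)CC3)cc2)cc1` gives 0.684, and compound 1 `O=C(CN1CCN(c2cc3c(cc2F)c(=O)c(C(=O)O)cn3C2CC2)CC1)Nc1ccc(C(=O)/C=C/c2ccc(Cl)cc2)cc1` gives 0.471, the two numbers within the scatter of each other. Going by the values given here, the only measured step, a number 0.21 log units higher from compound 1 to compound 2 (within the scatter), is small. Compound 3 `O=C(CN1CCN(c2cc3c(cc2F)c(=O)c(C(=O)O)cn3C2CC2)CC1)Nc1ccc(C(=O)/C=C/c2cccc([N+](=O)[O-])c2)cc1` is not yet measured; it differs from compound 2 by 3-nitrophenyl in place of 4-methoxyphenyl on a double-bonded chain carbon bound to a double-bonded chain carbon. Among the compounds with values here, no measured step covers this change, and the one step recorded concerned a different group. A modest decrease is nevertheless expected, a number 0.23 log units lower from compound 2 to compound 3 (within the scatter). Compound 3 is therefore estimated at 0.45, with a range from 0.1 to 0.8.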

Compound 3, partition coefficient: -0.0812
Estimate against measurement, compound 3: 0.53 log units above; measured number below the stated range.
By their numbers in this assay, from the lowest: compound 3; then compounds 1 and 2 (each within the scatter of the next).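

In this assay, 3-nitrophenyl on a double-bonded chain carbon bound to a double-bonded chain carbon gives a number 0.77 log units lower from compound 2 to compound 3 (beyond the scatter) and a number 0.55 log units lower from compound 1 to compound 3 (beyond the scatter) and so moves the read-out beyond the scatter, which the chloro to methoxy step did not. This position therefore does respond to a change of group. Nothing at hand accounts for the drop.

The compounds shown leave open whether the nitro group or its ring position carries the step. A 4-nitrophenyl or a 3-aminophenyl group would read on that question.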